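Two Acids Replace the Methyl Ester on the Amide Nitrogen

A few compounds are considered here, and "the series" means these few. Any claim that something is new, unique, unknown or untested is made for them only; others in the source may bear on it.

Measured compounds in a functional assay on BXPC-3 cells (Homo sapiens) for antiproliferative activity, read by MTT assay, with a stated time of 24 h; on this read-out lower numbers stand for stronger inhibition and higher numbers for weaker inhibition:
- compound 1 `CCn1c(C(=O)NCCC(=O)OC)ccc1C(CC)(CC)c1ccc(OCS(=O)(=O)c2ccccc2)c(C)c1`: > 50000 nM
- compound 2 `CCN(CC)CCNC(=O)c1ccc(C(CC)(CC)c2ccc(OCS(=O)(=O)c3ccccc3)c(C)c2)n1CC`: 6270 nM
- compound 3 `CCn1c(C(=O)N[C@H](CO)CCO)ccc1C(CC)(CC)c1ccc(OCS(=O)(=O)c2ccccc2)c(C)c1`: 15900 nM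

The value of compound 1 in this assay is a limit of the assay rather than a number. Compound 2 gives 6270 nM and compound 3 gives 15900 nM, so compound 1 sits at the weak end of the three, as the limit of > 50000 nM in this assay, at which 1 of the 3 values shown sits, shows.

The unmeasured compound 4 `CCn1c(C(=O)N[C@@H](CC(=O)O)C(=O)O)ccc1C(CC)(CC)c1ccc(OCS(=O)(=O)c2ccccc2)c(C)c1` differs from compound 1 by 1,2-dicarboxyethyl in place of 2-(methoxycarbonyl)ethyl on an amide-type nitrogen. Among the compounds with values here, no measured step makes this exact change. The two steps that leave the same position are an at least 7.9-fold lower number from compound 1 to compound 2 (0.90 log units; beyond the scatter) and an at least 3.1-fold lower number from compound 1 to compound 3 (0.49 log units; beyond the scatter), both being at least modest and both being bounded only on one side by the limit of compound 1. The step of a 2.5-fold higher number from compound 2 to compound 3 (0.40 log units; beyond the scatter) shows that the two replacements are not equal to each other.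

Since every known departure from the 2-(methoxycarbonyl)ethyl group gave a lower number, compound 4 is expected to show an at least 1.4-fold lower number from compound 1 to compound 4 (0.15 log units; that floor lies within the scatter), with wide uncertainty. The estimate for compound 4 in this assay is 35000 nM, within 8000 nM to 200000 nM, and a further limit is quite possible.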

Compound 4, half-maximal inhibitory concentration: > 50000 nM
Compound 4 gave a limit, no number; the forecaster's own chance of this, stated with the estimate: 55%; middle value at least 1.4-fold (0.15 log units) from the limit.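

Unlike the 2-(diethylamino)ethyl and 3-hydroxy-1-(hydroxymethyl)propyl groups, the 1,2-dicarboxyethyl group on the amide-type nitrogen yields no number in this assay, so a departure from the 2-(methoxycarbonyl)ethyl group does not always bring a readable value. Compound 4 and compound 1 both stop at a limit of the assay: the limit of > 50000 nM in this assay, at which 2 of the 4 values shown sit. The new compound shows an at least 3.1-fold higher number from compound 3 to compound 4 (0.49 log units; beyond the scatter) and an at least 7.9-fold higher number from compound 2 to compound 4 (0.90 log units; beyond the scatter), so among these groups the 1,2-dicarboxyethyl group stands clearly apart from the two that gave numbers.

From the compounds shown here alone, the step between the two limited compounds cannot be read, so their order stays unknown. Going by these compounds, it also stays open whether a single carboxylic acid, a primary amide or a longer chain ending in a diethylamino group would give a number at this position.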